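Silyl-protected cyclopentenone series: cytotoxicity working notes

A few compounds are considered here, and "the series" means these few. Any claim that something is new, unique, unknown or untested is made for them only; others in the source may bear on it.

Compound 1, `COc1ccc(C2=C(c3cc(OC)c(OC)c(OC)c3)C(=O)CC2O[SiH2]C(C)(C)C)cc1OC`, in an ADME assay on DU-145 cells (Homo sapiens) for cytotoxicity, read by MTT assay, with a stated time of 72 h (a lower number here means a stronger inhibitor, a higher number a weaker inhibitor), gives > 100 ug/mL, a limit of the assay and not a number.
Compound 2, `COc1ccc(C2=C(c3cc(OC)c(OC)c(OC)c3)C(=O)CC2O)cc1O`, in this assay gives 8 ug/mL.
Compound 3, `COc1cc(C2=C(c3ccccc3)C(O[SiH2]C(C)(C)C)CC2=O)cc(OC)c1OC`, in this assay gives > 100 ug/mL, again a limit and not a number.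

Compound 3 therefore stands only at the limit, with no measured number to place it. Compound 1 sits at the same limit, so the step that the two limits leave unreadable from compound 1 to compound 3 cannot be read in size or direction. Among the compounds with values here, the one measured number in the set belongs to compound 2, which differs from compound 3 in more than one place, so no single step can be drawn from it.

The next member, compound 4, `COc1ccc(C2=C(c3cc(OC)c(OC)c(OC)c3)C(=O)CC2O[SiH2]C(C)(C)C)cc1O`, differs from compound 3 by 3-hydroxy-4-methoxyphenyl in place of phenyl on a double-bonded ring carbon. Within the data shown here, the only step that touches the same position is a step that the two limits leave unreadable from compound 1 to compound 3, and because the limit of > 100 ug/mL in this assay, at which 2 of the 3 values shown sit, it remains unreadable. Among the measured compounds shown here, both silyl-bearing compounds so far sit at the limit, and the change here does not remove that silyl group, so compound 4 is expected to stay near that limit, with the free hydroxyl on the entering ring leaving some room for a measurable number. The estimate for compound 4 in this assay is 100 ug/mL, in the range 35 ug/mL to 300 ug/mL, which corresponds to an expected step of a number no higher from compound 3 to compound 4 (the limit leaves the size open) of no readable size.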

Compound 4, half-maximal inhibitory concentration: 75 ug/mL
Compound 4: the middle estimate sits 1.3-fold (0.12 log units) above what was measured; the range from low to high includes it.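

In this assay, compound 4 is the only silyl-bearing member shown with a measured number rather than a limit, which gives this position its first readable steps: the change on the double-bonded ring carbon gives an at least 1.3-fold lower number from compound 3 to compound 4 (0.12 log units; that floor lies within the scatter), and the change on the oxygen on an aromatic ring gives an at least 1.3-fold lower number from compound 1 to compound 4 (0.12 log units; that floor lies within the scatter). Measured against the free hydroxyl of compound 2, the group of 5 heavy atoms on the oxygen on a saturated carbon gives a 9.4-fold higher number from compound 2 to compound 4 (0.97 log units; beyond the scatter), so with this silyl group present the number is still measurable but clearly separated from that of compound 2. The two steps from the silyl-bearing compounds remain floors, with their true sizes open, because both start from a limit of the assay: the limit of > 100 ug/mL in this assay, at which 2 of the 4 values shown sit.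

The compounds shown leave open whether the gain in compound 4 comes from the hydroxyl itself or from the aromatic substitution pattern as a whole. They also leave open whether an amine in place of that hydroxyl, or a longer chain in place of the silyl group on the oxygen on a saturated carbon, would give a number closer to that of compound 2.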